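Cyano in place of fluoro: expectation for compound 4

The source may hold more compounds than are shown below. What is called first, only, known or untested is meant among the compounds shown, and "the series" means these compounds.

Measured in a functional assay (Nicotiana tabacum); a higher number here means a weaker inhibitor, a lower number a stronger inhibitor:
- compound 1 `CCCNc1nc(SC)nc2ncccc12`: 270 nM
- compound 2 `CCOCCNc1nc(SC)nc2ncccc12`: 7590 nM
- compound 3 `CSc1nc(Nc2ccc(F)cc2)c2cccnc2n1`: 2620 nM

Compound 3 holds the middle of the three numbers. Compound 1 lies lower and compound 2 lies higher, both gaps beyond the scatter.

Next in the series is compound 4 `CSc1nc(Nc2ccc(C#N)cc2)c2cccnc2n1`, which carries cyano in place of fluoro on an aromatic carbon, para to a large group: cyano in place of fluoro on an aromatic carbon.

Going by the values given here, the only measured step, a 28-fold higher number from compound 1 to compound 2 (1.45 log units; beyond the scatter), is large, but it concerns ethoxy in place of methyl on a saturated chain carbon, not the aromatic carbon changed here. It shows that a single change can move the number far, yet it gives neither size nor direction for this one. Among the compounds with values here, no measured pair varies the group on this ring. No step beyond the scatter is therefore expected in this assay, though with wide uncertainty either way.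

The expected change is a 1.1-fold higher number from compound 3 to compound 4 (0.03 log units; within the scatter). The estimated value for compound 4 is 2800 nM, with an expected range of 800 nM to 9000 nM.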

Compound 4, half-maximal inhibitory concentration: 7560 nM
Estimate against measurement, compound 4: 2.7-fold (0.43 log units) below; the range from low to high includes it.
By their numbers in this assay, from the lowest: compound 1; then compound 3; then compounds 4 and 2 (each within the scatter of the next).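

In this assay, going by these compounds alone, the only step on this ring is now available: cyano in place of fluoro on an aromatic carbon, para to a large group, gives a 2.9-fold higher number from compound 3 to compound 4 (0.46 log units; beyond the scatter) and so shows that the group at this carbon does move the number. Within the data shown here, the direction is upward, and this step is smaller than the chain change (a 28-fold higher number from compound 1 to compound 2 (1.45 log units; beyond the scatter)), so the earlier compounds could not have supplied its size or sign. No measurement available here accounts for the step.

With only fluoro and cyano at this carbon, two groups cannot show whether the number follows any trend across substituents. Hydrogen, methoxy, an amine or a carboxylic acid at the same carbon would test whether fluoro or cyano is unusual here, or whether the step from compound 3 extends to other groups.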